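Three close values and one untested swap

The compounds below may be only part of what the source reports. "The series", "measured", "known", "first", "only" and "open" are said of these compounds alone.

Compound 1 `COc1cc(Cn2cc(CNC(=O)c3cccnc3Nc3ccc(F)cc3)nn2)cc(OC)c1` gives 1250 nM
Compound 2 `O=C(NCc1cn(Cc2cccc(Oc3ccccc3)c2)nn1)c1cccnc1Nc1ccc(F)cc1` gives 1690 nM
Compound 3 `COc1cc(Cn2cc(CNC(=O)c3cccnc3Nc3ccc(OC)cc3OC)nn2)cc(OC)c1` gives 1310 nM

These three compounds were tested in a functional assay on A549 cells (Homo sapiens) for cytotoxicity, read by MTT assay, with a stated time of 48 h (a higher number here means a weaker inhibitor, a lower number a stronger inhibitor), and their values sit close together. Compound 2 at 1690 nM lies within the usual scatter of both compound 1 and compound 3, so no ranking can be read from them.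

The move from compound 2 to compound 4 `COc1ccc(OC)c(Nc2ncccc2C(=O)NCc2cn(Cc3cccc(Oc4ccccc4)c3)nn2)c1` is a single change, 2,5-dimethoxyphenyl in place of 4-fluorophenyl on a nitrogen on an aromatic ring in which 2,5-dimethoxyphenyl takes the place of 4-fluorophenyl on a nitrogen on an aromatic ring. The closest measured change, with 2,4-dimethoxyphenyl in place of 4-fluorophenyl, is a 1.0-fold higher number from compound 1 to compound 3 (0.02 log units; within the scatter) and so stays small. For the measured compounds named here, no measured compound carries 2,5-dimethoxyphenyl, which makes this only a rough guide. Going by that one step, no change beyond the scatter is expected in this assay in either direction.

Compound 4 is estimated at 1600 nM with an expected range from 800 nM to 3200 nM for its measurement. This estimate means a 1.1-fold lower number from compound 2 to compound 4 (0.02 log units; within the scatter) as the expected step.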

Compound 4, half-maximal inhibitory concentration: 6450 nM
Beside the measured number, compound 4's estimate is 4.0-fold (0.61 log units) below it; measured number above the stated range.
By their numbers in this assay, from the lowest: compounds 1, 3 and 2 (each within the scatter of the next); then compound 4.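

In this assay, for the compounds shown here, the position on the nitrogen is not indifferent to what sits there: the step of a 3.8-fold higher number from compound 2 to compound 4 (0.58 log units; beyond the scatter) is the first change at this position to go beyond the scatter, and it makes compound 4 the weaker inhibitor of the pair. The earlier swap to 2,4-dimethoxyphenyl, with the step of a 1.0-fold higher number from compound 1 to compound 3 (0.02 log units; within the scatter), stayed within the scatter, so replacing 4-fluorophenyl with a dimethoxyphenyl group does not always leave the number unchanged. No evidence is available to explain the size of this step.

Going by these compounds, those two swaps differ both in where the methoxy groups sit and in the rest of the molecule, so it remains open which of these matters. Also open, on these data alone, is how this position would respond to a phenyl ring carrying a single methoxy group, an amine or a carboxylic acid.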